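Rat distribution volume: estimating compound 4 from compound 3

This account rests on a few compounds, and the source may have more. Where it says the series, first, only, none or still open, it means among the compounds named here.

Measured in an ADME assay (Rattus norvegicus) for pharmacokinetics; a higher number here means that more of the compound sits outside the plasma, a lower number that more of the compound stays in the plasma:
compound 1 `COc1ccc2nc3c(nc2c1)O[C@H]1CN(C(=O)[C@H](C(C)(C)C)NC(=O)O[C@@H]2C[C@H]2CCCCC3)[C@H](C(=O)N[C@]2(C(=O)NS(=O)(=O)C3(C)CC3)C[C@H]2C(F)F)[C@@H]1C`: 2.2 L/kg
compound 2 `CC[C@@H]1[C@@H]2CN(C(=O)[C@H](C(C)(C)C)NC(=O)O[C@@H]3C[C@H]3CCCCCc3nc4ccc(OC)cc4nc3O2)[C@@H]1C(=O)N[C@]1(C(=O)NS(=O)(=O)C2(C)CC2)C[C@H]1C(F)F`: 1.7 L/kg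
compound 3 `C=C[C@@H]1C[C@]1(NC(=O)[C@@H]1[C@H](CC)[C@@H]2CN1C(=O)[C@H](C(C)(C)C)NC(=O)O[C@@H]1C[C@H]1CCCCCc1nc3ccc(OC)cc3nc1O2)C(=O)NS(=O)(=O)C1CC1`: 1.9 L/kg

Compound 3 sits between the other two numbers, with gaps to compound 2 and compound 1 both within the scatter. Among the compounds with values here, the one measured step, a 1.3-fold lower number from compound 1 to compound 2 (0.11 log units; within the scatter), concerns a different change, methyl in place of hydrogen on a saturated chain carbon, and is itself within the scatter. Compound 4 `CC[C@@H]1[C@@H]2CN(C(=O)[C@H](C(C)(C)C)NC(=O)O[C@@H]3C[C@H]3CCCCCc3nc4ccc(OC)cc4nc3O2)[C@@H]1C(=O)N[C@]1(C(=O)NS(=O)(=O)C2CC2)C[C@H]1CC` differs from compound 3 by ethyl in place of vinyl on a saturated ring carbon. Within the data shown here, no measured pair shows this change, so no direction can be drawn from the data. The expected step is no change at the digits printed from compound 3 to compound 4 (within the scatter), nothing beyond the scatter. Compound 4 is therefore expected to give about 1.9 L/kg in this assay, with a range from 1.2 L/kg to 3 L/kg.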

Compound 4, volume of distribution at steady state in the Rattus norvegicus assay: 3.1 L/kg
Beside the measured number, compound 4's estimate is 1.6-fold (0.21 log units) below it; measured number outside the range, above it.
By their numbers in the Rattus norvegicus assay, from the lowest: compounds 2, 3, 1 and 4 (each within the scatter of the next).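

Within the data shown here, in the Rattus norvegicus assay, ethyl in place of vinyl on this saturated ring carbon gives a 1.6-fold higher number from compound 3 to compound 4 (0.21 log units; within the scatter), the first reading of this change at this position, and it stays inside the usual scatter of the distribution volume. In a physicochemical assay for lipophilicity (on this read-out lower numbers stand for lower lipophilicity and higher numbers for higher lipophilicity), compound 3 gives 4.1 and compound 4 gives 4.6. In the physicochemical assay the same change lies beyond the scatter, so on this pair ethyl carries more lipophilicity than vinyl: the measured distribution coefficient of compound 3, 4.1, and of compound 4, 4.6, a number 0.50 log units higher (beyond the scatter)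

As far as these compounds go, with a single pair, whether distribution volume follows lipophilicity at this position remains open. Also open, from the compounds shown here alone, is what a propyl chain or an amine on this ring carbon would do to either read-out.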